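The source may hold more compounds than are shown below. What is called first, only, known or untested is meant among the compounds shown, and "the series" means these compounds.

Working notes on the series. In a functional assay on cells (Platelet, Homo sapiens) for inhibition (a lower number here means a stronger inhibitor, a higher number a weaker inhibitor), compound 1 `CCOC(=O)c1ccc(-c2nn(Cc3ccccc3F)c3ccccc23)cc1` gives only a limit, > 10000 nM. Compound 2 `CCOC(=O)c1ccc(-c2nn(-c3ccco3)c3ccccc23)cc1` likewise gives only a limit in this assay, > 10000 nM. For the measured compounds named here, the one measured step, a step that the two limits leave unreadable from compound 1 to compound 2, has no readable size or direction, since both of its ends sit at the limit of > 10000 nM in this assay, at which 2 of the 2 values shown sit. Compound 2 therefore stands at the edge of what this assay reports, with no number of its own and nothing placing it against compound 1.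

Compound 3 `CCOC(=O)c1ccc(-c2nn(-c3ccccc3)c3ccccc23)cc1` differs from compound 2 by phenyl in place of furan-2-yl on an aromatic nitrogen. Going by the values given here, the only measured step that touches this position is a step that the two limits leave unreadable from compound 1 to compound 2, and it cannot be sized because both values rest on (the limit of > 10000 nM in this assay, at which 2 of the 2 values shown sit). Among the compounds with values here, no measured step thus gives a direction or a magnitude for the change into compound 3. The expectation is that compound 3, like compound 2 with its > 10000 nM, will again return only a limit in this assay. The estimated step from compound 2 to compound 3 is a step that the limit leaves unreadable from compound 2 to compound 3, not beyond the scatter. Compound 3 is expected at 15000 nM, with a range from 3000 nM to 80000 nM.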

Compound 3, half-maximal inhibitory concentration: > 10000 nM
Compound 3: no number, only a limit; the forecaster's own chance of this, stated with the estimate: 80%; the middle value does not contradict the limit.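

In this assay compound 3 gives > 10000 nM as a limit and not a number. For the compounds shown here, no step among compound 1, compound 2 and compound 3 can be read, in size or direction, because all three rest on the same limit: the limit of > 10000 nM in this assay, at which 3 of the 3 values shown sit. The compounds shown leave open whether any group on the aromatic nitrogen of the shared core would give a measurable value in this assay at all.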